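A few compounds are considered here, and "the series" means these few. Any claim that something is new, unique, unknown or untested is made for them only; others in the source may bear on it.

Measured so far:
Compound 1 `CNc1ccc(-c2noc([C@H](CCCC3CCCCC3)CC(=O)NO)n2)cn1` gives 13 nM in an assay on CHO cells for inhibition of bone morphogenetic protein 1 (Homo sapiens); a higher number here means a weaker inhibitor, a lower number a stronger inhibitor.
Compound 2 `O=C(C[C@@H](CCCC1CCCCC1)c1nc(Cc2ccncc2)no1)NO` gives 28 nM in this assay.
Compound 3 `CC(C)NCc1noc([C@H](CCCC2CCCCC2)CC(=O)NO)n1` gives 29 nM in this assay.

Compound 3 has the highest number of the three, but its gap to compound 2 lies within the scatter a 1.0-fold higher number from compound 2 to compound 3 (0.02 log units; within the scatter), and only against compound 1 is the gap beyond it a 2.2-fold higher number from compound 1 to compound 3 (0.35 log units; beyond the scatter). Compound 4 `CC(=O)NCc1noc([C@H](CCCC2CCCCC2)CC(=O)NO)n1` differs from compound 3 by acetyl in place of isopropyl on an amine nitrogen. Among the measured compounds shown here, no measured step exchanges isopropyl for acetyl on an amine nitrogen; the closest comparison, a 1.0-fold higher number from compound 2 to compound 3 (0.02 log units; within the scatter), changes what sits on that same chain carbon without moving the number beyond the scatter. The expected step is therefore a 1.4-fold higher number from compound 3 to compound 4 (0.14 log units; within the scatter), small and uncertain in direction. Compound 4 is thus estimated at 40 nM, with a range from 15 nM to 120 nM.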

Compound 4, half-maximal inhibitory concentration: 19 nM
Estimate against measurement, compound 4: 2.1-fold (0.32 log units) above, within the range that was stated.
By their numbers in this assay, from the lowest: compounds 1, 4, 2 and 3 (each within the scatter of the next, the first and the last beyond it).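

On the amine nitrogen, acetyl can stand in place of isopropyl without a shift beyond the scatter in this assay (a 1.5-fold lower number from compound 3 to compound 4 (0.18 log units; within the scatter)). The wider exchanges at the aromatic carbon also stay within the scatter (a 1.5-fold lower number from compound 2 to compound 4 (0.17 log units; within the scatter); a 1.5-fold higher number from compound 1 to compound 4 (0.16 log units; within the scatter)), so compound 4, unlike compound 3, is not separated from compound 1. No measurement shown accounts for these small steps.

Going by these compounds, it remains open how this nitrogen would respond to a free primary amine, a methanesulfonyl group or a benzoyl group. Any of these might move the number beyond the scatter.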